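This account rests on a few compounds, and the source may have more. Where it says the series, first, only, none or still open, it means among the compounds named here.

Of the compounds shown here, three built on one shared core have been measured. Compound 1 `Cc1ccccc1-c1c(C)nn(-c2nc(-c3ccc(Cl)c(Cl)c3)c(SC(C)C)s2)c1C(=O)O` gives 5500 nM in a functional assay on BJAB cells (Homo sapiens) for antiproliferative activity, with a stated time of 4 days; on this read-out higher numbers stand for an effect only at larger amounts of compound and lower numbers for an effect already at smaller amounts. Compound 2 `Cc1nn(-c2nc(-c3ccc(Cl)c(Cl)c3)c(SC(C)C)s2)c(C(=O)O)c1-c1cccc(C(F)(F)F)c1` gives 22000 nM in this assay, and compound 3 `Cc1nn(-c2nc(-c3ccc(Cl)c(Cl)c3)c(SC(C)C)s2)c(C(=O)O)c1-c1cc(C(F)(F)F)cc(C(F)(F)F)c1` gives 1800 nM. Among these three, compound 2 stands at the highest number: the step of a 4.0-fold higher number from compound 1 to compound 2 (0.60 log units; beyond the scatter) runs against it, and the step of a 12-fold lower number from compound 2 to compound 3 (1.09 log units; beyond the scatter) runs in its favour, so compound 2 is the weakest of the three on this read-out.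

The next compound, compound 4 `COc1cccc(-c2c(C)nn(-c3nc(-c4ccc(Cl)c(Cl)c4)c(SC(C)C)s3)c2C(=O)O)c1`, has not yet been measured. It differs from compound 2 in one place: methoxy in place of trifluoromethyl on an aromatic carbon.

Neither measured step probes this change directly. Going by the values given here, the step from compound 1 to compound 2 swaps one whole aryl group for another, and the step from compound 2 to compound 3 adds a second trifluoromethyl; no measured pair shows a methoxy on this ring at all. What the data do show is that the aryl substituent pattern moves this assay by steps of modest to large size in either direction. Without a closer precedent, compound 4 is expected to sit near compound 2, with a step of a 1.5-fold lower number from compound 2 to compound 4 (0.17 log units; within the scatter) that is not expected to exceed the scatter. Compound 4 is therefore estimated at 15000 nM, with a range from 4000 nM to 50000 nM.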

Compound 4, half-maximal effective concentration: 14000 nM
Estimate against measurement, compound 4: 1.1-fold (0.03 log units) above; low and high end bracket the measured number.
By their numbers in this assay, from the lowest: compound 3; then compound 1; then compounds 4 and 2 (each within the scatter of the next).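

In this assay, methoxy in place of trifluoromethyl on this aromatic carbon, meta to a large group, gives a 1.6-fold lower number from compound 2 to compound 4 (0.20 log units; within the scatter) and so leaves the read-out without a change that can be told from the scatter, even though methoxy carries a hydrogen-bond acceptor and trifluoromethyl carries none. The change from 2-methylphenyl to 3-methoxyphenyl gives a 2.5-fold higher number from compound 1 to compound 4 (0.41 log units; beyond the scatter) and runs the same way as a 4.0-fold higher number from compound 1 to compound 2 (0.60 log units; beyond the scatter) for 3-(trifluoromethyl)phenyl, so both groups with a single substituent at this place stand at higher numbers than the 2-methylphenyl, while these two cannot be separated from each other. No measurement at hand gives a reason for either of these steps.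

As far as these compounds go, whether an amine, a hydroxyl or a nitrile at this place would leave the number as unchanged as methoxy does remains open. From the compounds shown here alone, it is also open whether the step of a 12-fold lower number from compound 2 to compound 3 (1.09 log units; beyond the scatter) that comes with a second trifluoromethyl has any counterpart with a second methoxy on the same ring, or whether it belongs to trifluoromethyl alone.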